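This account rests on a few compounds, and the source may have more. Where it says the series, first, only, none or still open, it means among the compounds named here.

In a functional assay on MDA-MB-435 cells (Homo sapiens) for inhibition (on this read-out higher numbers stand for weaker inhibition of growth and lower numbers for stronger inhibition of growth), three compounds have been measured so far:
- compound 1 `NS(=O)(=O)c1ccc(/C=C/c2ccc(O)c(O)c2)cc1` gives 16800 nM here
- compound 2 `NS(=O)(=O)c1ccc(/C=C/c2ccc(F)cc2)cc1` gives 27000 nM here
- compound 3 `NS(=O)(=O)c1ccc(/C=C/c2ccc(O)cc2)cc1` gives 20300 nM here

Compound 3 stands level with the other two within the usual scatter, so these three numbers cannot be ranked. The next compound to consider is compound 4 `CN(C)c1ccc(/C=C/c2ccc(S(N)(=O)=O)cc2)cc1`, which has not yet been measured. Its difference from compound 3 is dimethylamino in place of hydroxy on an aromatic carbon and amounts to dimethylamino in place of hydroxy on an aromatic carbon, para to a large group.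

Among the compounds with values here, two measured steps bear on this. The closer guide is a 1.3-fold lower number from compound 2 to compound 3 (0.12 log units; within the scatter) and involves a swap of hydroxy for fluoro on an aromatic carbon. The other is a 1.2-fold higher number from compound 1 to compound 3 (0.08 log units; within the scatter) and involves hydrogen in place of hydroxy. Both are small, so no step beyond the scatter is expected. However, no measured compound carries dimethylamino, which leaves the range wide. The expected change is a 1.1-fold lower number from compound 3 to compound 4 (0.05 log units; within the scatter) on this estimate. Compound 4 is estimated at 18000 nM in this assay with 6000 nM to 45000 nM as the expected range.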

Compound 4, concentration for 50% growth inhibition: 7630 nM
The estimate for compound 4 lay 2.4-fold (0.37 log units) above the measured number; the measured number falls inside the stated range.
By their numbers in this assay, from the lowest: compound 4; then compounds 1, 3 and 2 (each within the scatter of the next).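

Within the data shown here, at the position on an aromatic carbon para to a large group, dimethylamino gives the first changes beyond the usual scatter in this assay, with a 2.7-fold lower number from compound 3 to compound 4 (0.42 log units; beyond the scatter) when it replaces hydroxy and a 3.5-fold lower number from compound 2 to compound 4 (0.55 log units; beyond the scatter) when it replaces fluoro. Both steps are modest, but they show that growth inhibition in this series can respond to the group at this position, which the earlier swaps among hydrogen, hydroxy and fluoro, all within the scatter, could not show. Dimethylamino differs from hydroxy in its heavy atoms and in having no hydrogen-bond donor, and no measurement here explains the change or tells which difference matters.

As far as these compounds go, it remains open whether the plain amino group, methylamino or diethylamino would give a similar number. A methoxy group at the same position would offer a further comparison with both hydroxy and dimethylamino.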